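The source may hold more compounds than are shown below. What is called first, only, known or untested is meant among the compounds shown, and "the series" means these compounds.

Measured compounds in a functional assay on HT-29 cells (Homo sapiens) for antiproliferative activity, read by MTT assay, with a stated time of 72 h; on this read-out lower numbers stand for stronger inhibition and higher numbers for weaker inhibition:

compound 1 `CN(C)CCn1cnnc1-c1cc(Oc2ccc(NC(=O)Nc3ccccc3C(F)(F)F)cc2F)ccn1` gives 5860 nM
compound 2 `CN(C)CCn1cnnc1-c1cc(Oc2ccc(NC(=O)Nc3ccc(F)c(F)c3)cc2F)ccn1` gives 3620 nM
compound 3 `CN(C)CCCn1cnnc1-c1cc(Oc2ccc(NC(=O)Nc3ccccc3C(F)(F)F)cc2F)ccn1` gives 3130 nM

All three share a diaryl ether urea framework and differ in two places. From compound 1 to compound 2 the change is 3,4-difluorophenyl in place of 2-(trifluoromethyl)phenyl on an amide-type nitrogen, and the step it made was a 1.6-fold lower number from compound 1 to compound 2 (0.21 log units; within the scatter). From compound 1 to compound 3 the difference is (dimethylamino)methyl in place of dimethylamino on a saturated chain carbon, two bonds along the chain from an aromatic nitrogen, with the step of a 1.9-fold lower number from compound 1 to compound 3 (0.27 log units; within the scatter). Among the measured compounds shown here, neither step reaches beyond the usual scatter of this assay, so the three values are treated as lying close together, and no compound is singled out as the most active among them.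

The unmeasured compound 4 `CN(C)CCCn1cnnc1-c1cc(Oc2ccc(NC(=O)Nc3ccc(F)c(F)c3)cc2F)ccn1` carries both changes at once. Relative to compound 3 it differs by 3,4-difluorophenyl in place of 2-(trifluoromethyl)phenyl on an amide-type nitrogen, which is the same change as that from compound 1 to compound 2; the two "place" descriptions agree word for word, so it is regarded as the same change made on the core of compound 3 rather than on the core of compound 1. For the measured compounds named here, the only measured instance of this change is a 1.6-fold lower number from compound 1 to compound 2 (0.21 log units; within the scatter), and the expectation for compound 4 rests on that single step transferring to the new core. The step from compound 3 to compound 4 is therefore estimated at a 1.5-fold lower number from compound 3 to compound 4 (0.17 log units; within the scatter), a value that is expected to stay within the scatter because the earlier step of a 1.6-fold lower number from compound 1 to compound 2 (0.21 log units; within the scatter) did so as well. With compound 3 at 3130 nM as the starting point, compound 4 is expected to give about 2100 nM in this assay, with a plausible range from 900 nM to 4800 nM.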

Compound 4, half-maximal inhibitory concentration: 1210 nM
Estimate against measurement, compound 4: 1.7-fold (0.24 log units) above; the measured number falls inside the stated range.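

In this assay, 3,4-difluorophenyl in place of 2-(trifluoromethyl)phenyl on the amide-type nitrogen gives a 2.6-fold lower number from compound 3 to compound 4 (0.41 log units; beyond the scatter), and this step does not differ from the earlier one on the other core: the same change on two cores in this assay, a 1.6-fold lower number (0.21 log units; within the scatter) from compound 1 to compound 2 and a 2.6-fold lower number (0.41 log units; beyond the scatter) from compound 3 to compound 4, 1.6-fold (0.20 log units) apart, within the scatter of two such steps

The second change, (dimethylamino)methyl in place of dimethylamino on the saturated chain carbon, gives a 3.0-fold lower number from compound 2 to compound 4 (0.48 log units; beyond the scatter), and it likewise agrees with its earlier counterpart: the same change on two cores in this assay, a 1.9-fold lower number (0.27 log units; within the scatter) from compound 1 to compound 3 and a 3.0-fold lower number (0.48 log units; beyond the scatter) from compound 2 to compound 4, 1.6-fold (0.20 log units) apart, within the scatter of two such steps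

Both changes therefore carry from one core to the other in this small set, with no sign that either depends on the other, although each step that crosses the scatter on the second core has a counterpart on the first that stays within it; the larger size of the new steps cannot be read as a real gain on that core, and one pair of steps per change, in a single cell line, shows nothing about transfer to cores beyond these four compounds.

Open, as far as these compounds go, is whether the same transfer holds for other groups on the amide-type nitrogen, such as an unsubstituted phenyl or a chlorophenyl. Also open, from the compounds shown here alone, is how a still longer chain, or a cyclic amine in place of the dimethylamino end, would behave on either core.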